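This account rests on a few compounds, and the source may have more. Where it says the series, first, only, none or still open, it means among the compounds named here.

So far, two compounds built on the shared core have been measured in an ADME assay on THP-1 cells (Homo sapiens) for cytotoxicity, read by flow cytometry and propidium iodide staining, with a stated time of 72 h (on this read-out higher numbers stand for weaker inhibition and lower numbers for stronger inhibition), on this scale. There, compound 1 (`CC(=O)Nc1ccc2oc(-c3cccc(C(F)(F)F)c3)cc(=O)c2c1`) gives 50000 nM and compound 2 (`COc1cccc(-c2oc3ccc(NC(C)=O)cc3c(=O)c2OC)c1`) gives 5000 nM as its value. Compound 2 therefore holds the lower of the two numbers, and its gap to compound 1 lies beyond the scatter. These two compounds differ in more than one place, so their gap does not isolate any single change. Compound 3 (`COc1c(-c2cccc(C(F)(F)F)c2)oc2ccc(NC(C)=O)cc2c1=O`) has not yet been measured. Relative to compound 2, it carries trifluoromethyl in place of methoxy on an aromatic carbon, meta to a large group (trifluoromethyl in place of methoxy on an aromatic carbon). Among the compounds with values here, no measured pair shows this change alone, so the expectation remains loose. Compound 1 also carries trifluoromethyl and gives 50000 nM in this assay and this points to weaker inhibition as the expected direction. The estimated move is a 2.4-fold higher number from compound 2 to compound 3 (0.38 log units; beyond the scatter) and it is expected to lie only modestly beyond the scatter. The estimate for compound 3 is 12000 nM and a range from 4000 nM to 40000 nM is expected.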

Compound 3, half-maximal inhibitory concentration: 52000 nM
Beside the measured number, compound 3's estimate is 4.3-fold (0.64 log units) below it; measured number above the stated range.
By their numbers in this assay, from the lowest: compound 2; then compounds 1 and 3 (each within the scatter of the next).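

In this assay, within the data shown here, trifluoromethyl in place of methoxy on an aromatic carbon, meta to a large group, gives a 10-fold higher number from compound 2 to compound 3 (1.02 log units; beyond the scatter), a large step and the first reading of this change on its own. The other change, methoxy in place of hydrogen on an aromatic carbon, gives a 1.0-fold higher number from compound 1 to compound 3 (0.02 log units; within the scatter), which lies within the scatter, so with trifluoromethyl on the ring this added methoxy makes no measurable difference in this pair. Nothing available here bears on why the ring methoxy of compound 2 goes with the lower number.

The compounds shown leave open whether the effect of swapping the ring methoxy for trifluoromethyl holds when hydrogen, as in compound 1, replaces the other methoxy, since only the pair with that second methoxy in place can be read. They also leave open whether the lower number is specific to methoxy at this place on the ring, or whether a hydroxyl group, an amine or a chlorine atom there would give a number like that of compound 2 or one like that of compound 3.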